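A Third Methoxy Group on the Carbonyl-Side Ring

The source may hold more compounds than are shown below. What is called first, only, known or untested is meant among the compounds shown, and "the series" means these compounds.

Of the compounds shown here, three sharing one core have been measured in a functional assay on MCF7 cells (Homo sapiens) for inhibition, read by MTT assay, with a stated time of 48 h; a higher number here means a weaker inhibitor, a lower number a stronger inhibitor. Compound 1 `COc1cc(-c2cc(/C=C/C(=O)c3ccc(N)cc3)[nH]n2)cc(OC)c1OC` gives 1600 nM, compound 2 `COc1ccc(C(=O)/C=C/c2cc(-c3cc(OC)c(OC)c(OC)c3)n[nH]2)cc1OC` gives 510 nM, and compound 3 `COc1cc(-c2cc(/C=C/C(C)=O)[nH]n2)cc(OC)c1OC` gives 20100 nM. Compound 2 stands lowest of the three: the step of a 3.1-fold lower number from compound 1 to compound 2 (0.50 log units; beyond the scatter) and the step of a 39-fold higher number from compound 2 to compound 3 (1.60 log units; beyond the scatter) both set it apart beyond the scatter, and a 13-fold higher number from compound 1 to compound 3 (1.10 log units; beyond the scatter) shows again that the group on the carbonyl carbon governs the number. Compound 4 `COc1cc(C(=O)/C=C/c2cc(-c3cc(OC)c(OC)c(OC)c3)n[nH]2)cc(OC)c1OC` differs from compound 2 in one place: methoxy in place of hydrogen on an aromatic carbon. Going by the values given here, none of the measured steps bears directly on this change; all three swap the whole group on the carbonyl carbon, moving the number by modest to large amounts, whereas here the ring is kept and one methoxy is added. Compound 4 is therefore expected to stay near compound 2. The implied step a 1.0-fold lower number from compound 2 to compound 4 (0.01 log units; within the scatter) is expected to lie within the scatter in this assay. Compound 4 is estimated at 500 nM, with a range from 150 nM to 1600 nM.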

Compound 4, half-maximal inhibitory concentration: 430 nM
Estimate against measurement, compound 4: 1.2-fold (0.07 log units) above; low and high end bracket the measured number.
By their numbers in this assay, from the lowest: compounds 4 and 2 (each within the scatter of the next); then compound 1; then compound 3.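

In this assay, adding methoxy on an aromatic carbon ortho to a methoxy group gives a 1.2-fold lower number from compound 2 to compound 4 (0.07 log units; within the scatter), so this ring position accepts the added group without a change beyond the scatter. The earlier steps shown here all replaced the whole group on the carbonyl carbon and moved the number beyond the scatter; this one shows that a single substitution on the retained ring need not do so. Nothing measured here explains why the number holds at this position.

The compounds shown leave open whether a hydroxyl group, a chlorine atom or an amine on this same aromatic carbon would also stay within the scatter of compound 2. They also leave open whether a longer chain, such as ethoxy in place of the added methoxy, would do the same.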